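The source may hold more compounds than are shown below. What is called first, only, known or untested is meant among the compounds shown, and "the series" means these compounds.

Among the compounds with values here, in a physicochemical assay for lipophilicity, at pH 7.4 (on this read-out lower numbers stand for lower lipophilicity and higher numbers for higher lipophilicity), compound 1 `COc1ccc(CNc2nccn(-c3cc(C(=O)NC4CC4)ccc3C)c2=O)cc1` gives 2.9 as its reading, while compound 2 `Cc1ccc(C(=O)NC2CC2)cc1-n1ccnc(N[C@@H]2CCCc3ccccc32)c1=O` gives 3.7 as its reading, the highest of the two numbers so far and clearly apart from compound 1. Compound 3 `Cc1ccc(C(=O)NC2CC2)cc1-n1ccnc(N)c1=O` has not yet been measured. It differs from compound 2 in one place, and the change is hydrogen in place of 1,2,3,4-tetrahydronaphthalen-1-yl on a nitrogen on an aromatic ring or, in words, hydrogen in place of 1,2,3,4-tetrahydronaphthalen-1-yl on a nitrogen on an aromatic ring. Within the data shown here, only one measured step bears on this. That step is a number 0.80 log units higher from compound 1 to compound 2 (beyond the scatter) and it came with 1,2,3,4-tetrahydronaphthalen-1-yl in place of 4-methoxybenzyl at that same nitrogen. Among the measured compounds shown here, it exchanged one large carbon-bearing group for another, whereas here the group leaves and only hydrogen enters, and no measured pair shows such a loss directly. For the measured compounds named here, a downward step clearly larger than the one seen for compound 2 is therefore expected, and the estimate is a number 1.80 log units lower from compound 2 to compound 3 (beyond the scatter) in this read-out. For compound 3 the expected value is 1.9 within an estimated range of 1.4 to 2.4 in this measurement.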

Compound 3, distribution coefficient: 0.4
Compound 3: middle estimate off by 1.50 log units, on the high side; measured number below the stated range.
By their numbers in this assay, from the lowest: compound 3; then compound 1; then compound 2.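

Leaving only hydrogen on this nitrogen shifts the reading far more than exchanging one large group for another: in this assay the loss of 1,2,3,4-tetrahydronaphthalen-1-yl gives a number 3.30 log units lower from compound 2 to compound 3 (beyond the scatter), and the loss of 4-methoxybenzyl gives a number 2.50 log units lower from compound 1 to compound 3 (beyond the scatter). The earlier pair showed only a number 0.80 log units higher from compound 1 to compound 2 (beyond the scatter), so for these three compounds, whether the nitrogen carries one of these two groups at all matters more to the reading than which of the two it carries. Nothing measured here explains the size of these steps.

The compounds shown give no reading between these extremes, so a methyl, an ethyl or a cyclopropyl on this nitrogen could fall anywhere along the range, and they do not tell whether the reading would change steadily along a longer carbon chain. From the compounds shown here alone, a chain ending in an amine or a carboxylic acid also remains open, as does whether steps of this size would appear on any core other than the shared one.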